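This account rests on a few compounds, and the source may have more. Where it says the series, first, only, none or still open, it means among the compounds named here.

Measured in a functional assay on HepG2 cells (Homo sapiens) for inhibition, read by MTT assay, with a stated time of 24 h; on this read-out higher numbers stand for weaker inhibition and lower numbers for stronger inhibition:
compound 1 `CC1(C)[C@H]2CC[C@]1(C)N(Cc1cn(-c3ccc(O)cc3)nn1)C(=O)C2` gives 80 nM
compound 2 `Cc1ccc(-n2cc(CN3C(=O)C[C@@H]4CC[C@@]3(C)C4(C)C)nn2)cc1` gives 480 nM
compound 3 `Cc1ccccc1-n1cc(CN2C(=O)C[C@@H]3CC[C@@]2(C)C3(C)C)nn1` gives 150 nM

Compound 3 sits with compound 1 at the lower end of these numbers. The data show a 1.9-fold higher number from compound 1 to compound 3 (0.27 log units; within the scatter) and a 3.2-fold lower number from compound 2 to compound 3 (0.51 log units; beyond the scatter).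

The next compound is compound 4 `CC1(C)[C@H]2CC[C@]1(C)N(Cc1cn(-c3cccc(Br)c3)nn1)C(=O)C2`, with 3-bromophenyl in place of 2-methylphenyl on an aromatic nitrogen.

Among the measured compounds shown here, no measured compound carries 3-bromophenyl, so no measured step covers this change directly. The closest evidence comes from the other changes at the same aromatic nitrogen, which include a 6.0-fold higher number from compound 1 to compound 2 (0.78 log units; beyond the scatter) as well as the two steps to compound 3. Both steps beyond the scatter are modest, so a large step is not expected in this assay. Any lean is upward: compound 2, which lacks 2-methylphenyl, gives 480 nM as the highest number. Compound 1 goes against this lean, since it also lacks that group yet stays within the scatter of compound 3.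

The estimated step is a 1.5-fold higher number from compound 3 to compound 4 (0.17 log units; within the scatter) and is expected to stay within the scatter. For compound 4 the estimated value is 220 nM with an expected range from 70 nM to 700 nM.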

Compound 4, half-maximal inhibitory concentration: 20 nM
Compound 4: the middle estimate sits 11-fold (1.04 log units) above what was measured; the measured number lies below the stated range.
By their numbers in this assay, from the lowest: compound 4; then compounds 1 and 3 (each within the scatter of the next); then compound 2.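

Among the compounds shown here, the aryl group on the aromatic nitrogen can take the number in this assay lower than the earlier compounds showed: 3-bromophenyl in place of 2-methylphenyl gives a 7.5-fold lower number from compound 3 to compound 4 (0.88 log units; beyond the scatter), and the same group in place of 4-methylphenyl gives a 24-fold lower number from compound 2 to compound 4 (1.38 log units; beyond the scatter), the one large step in this set. Compound 4 also goes beyond the previous low end, with a 4.0-fold lower number from compound 1 to compound 4 (0.60 log units; beyond the scatter), so a hydroxy group on the phenyl ring is not required for a low number here. The groups leaving and entering in the step from compound 3 match in their counts of heavy atoms, hydrogen-bond donors and hydrogen-bond acceptors, so these counts do not separate the two compounds. No measurement available here accounts for the drop in the number.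

For the compounds shown here, whether the low number of compound 4 depends on bromine itself or on where it sits on the phenyl ring stays open, as bromine appears at only one ring position in this set. Also open, from the compounds shown here alone, is how chlorine, methoxy, an amine or a carboxylic acid would compare with bromine at that same ring position on the shared core.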